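Dropping one chloro from the core of compound 1

The source may report more compounds than this note shows. Statements on the series, on what has been measured and on what is new or still open speak of the compounds shown alone.

Measured compounds:
Compound 1, `ClCc1cccc(Cn2cnc3c(Cl)nc(Cl)nc32)c1`: 6910 nM
Compound 2, `ClCc1ccc(Cn2cnc3c(Cl)nc(Cl)nc32)cc1`: 3800 nM
Compound 3, `ClCc1ccc(Cn2cnc3nc(Cl)nc(Cl)c32)cc1`: 3540 nM

The three compounds were tested in a functional assay on HCT-15 cells (Homo sapiens) for cytotoxicity, read by sulforhodamine B assay, with a stated time of 48 h; a lower number here means a stronger inhibitor of growth, a higher number a weaker inhibitor of growth. Compound 1 shows the highest number of the three, but its gaps to compound 2 and to compound 3 both fall within the usual scatter of this kind of measurement, so the three cannot be put in order on these numbers alone; they behave as roughly equal growth inhibitors.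

The unmeasured compound 4, `ClCc1cccc(Cn2cnc3c(Cl)ncnc32)c1`, is reached from compound 1 by a single change: hydrogen in place of chloro on an aromatic carbon. In words, hydrogen takes the place of chloro on an aromatic carbon of the shared core, on the six-membered aromatic ring with 2 nitrogen, between two ring nitrogen atoms. Among the compounds with values here, no pair of measured compounds differs in this way, so there is no measured step to lean on.

Within the data shown here, with no such step available, the expectation rests on caution: the step from compound 1 to compound 4 in this assay is expected to be small, most likely a slightly higher number, and possibly none beyond the scatter. Compound 4 is therefore estimated at 9000 nM, with a range from 3500 nM to 25000 nM, meaning an expected change of a 1.3-fold higher number from compound 1 to compound 4 (0.11 log units; within the scatter).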

Compound 4, concentration for total growth inhibition: 4670 nM
Estimate against measurement, compound 4: 1.9-fold (0.28 log units) above; measured number inside the range.
By their numbers in this assay, from the lowest: compounds 3, 2, 4 and 1 (each within the scatter of the next).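

In this assay, hydrogen in place of chloro on this aromatic carbon of the shared core, between two ring nitrogen atoms, gives a 1.5-fold lower number from compound 1 to compound 4 (0.17 log units; within the scatter), so compound 1 and compound 4 cannot be told apart as growth inhibitors. All three earlier compounds carried this chloro and so gave no view of the position without it, whereas compound 4 shows that growth inhibition of the same order is kept in a compound that lacks it, at least in these cells. No accompanying measurement offers an explanation for this result.

Chloro and hydrogen are the only two groups seen at this position, so it remains open whether something quite different there, such as an amine, a methoxy group or a longer chain, would give a step larger than the scatter. Going by these compounds, it also remains open whether the other chloro on the core can be replaced by hydrogen in the same way, and whether the same replacement would give a similar result with the side chain arranged as in compound 2.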